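A few compounds are considered here, and "the series" means these few. Any claim that something is new, unique, unknown or untested is made for them only; others in the source may bear on it.

Working notes on the series.

In a functional assay on cells (Neutrophil, Rattus norvegicus, strain Sprague-Dawley) for inhibition (a lower number here means a stronger inhibitor, a higher number a weaker inhibitor), compound 1 `O=C/C=C/c1ccccc1OCc1ccccc1` gives 6400 nM, the highest of the three numbers recorded so far. Compound 2 `O=C/C=C/c1ccccc1OCc1cccc(Cl)c1` gives 5900 nM in this assay, and compound 3 `O=C/C=C/c1ccccc1OCc1ccccc1F` gives 3300 nM in this assay. Both measured steps start from compound 1 and each puts a single halogen on an aromatic carbon of the same ring: a 1.1-fold lower number from compound 1 to compound 2 (0.04 log units; within the scatter), and a 1.9-fold lower number from compound 1 to compound 3 (0.29 log units; within the scatter). Neither leaves the scatter, so the numbers of compounds 1, 2 and 3 cannot be ordered.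

Compound 4 `Cc1ccc(COc2ccccc2/C=C/C=O)cc1` follows the same pattern of change: methyl in place of hydrogen on an aromatic carbon. Going by the values given here, no measured step shows a methyl at this place, so the two halogen steps are the only guide. As both stayed within the scatter, a step of similar size, in no reliable direction, is expected in this assay. Compound 4 is therefore expected to give about 5000 nM in this assay, a step of a 1.3-fold lower number from compound 1 to compound 4 (0.11 log units; within the scatter) that stays inside the scatter. The estimated range for compound 4 runs from 2500 nM to 10000 nM.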

Compound 4, half-maximal inhibitory concentration: 11000 nM
For compound 4 the middle estimate is 2.2-fold (0.34 log units) below the measured one; the whole stated range lies below it.
By their numbers in this assay, from the lowest: compounds 3, 2, 1 and 4 (each within the scatter of the next, the first and the last beyond it).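

In this assay, the methyl gives the series its first carbon substituent on this ring, here para to a large group, and the step is a 1.7-fold higher number from compound 1 to compound 4 (0.24 log units; within the scatter). Like the two halogen steps, this one gives no readable change, so a single methyl at this position cannot be told apart from the hydrogen of compound 1. Nothing measured here bears on the reason for this result.

Still open, as far as these compounds go, is whether anything at this position can move the number beyond the scatter, for example an amine, a carboxylic acid or a longer chain in place of the methyl. Also open, from the compounds shown here alone, is whether the same methyl would give a readable step at the other places on this ring, or whether changes to the rest of the core of compound 1 matter more.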